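This account rests on a few compounds, and the source may have more. Where it says the series, first, only, none or still open, it means among the compounds named here.

Measured so far in an ADME assay on microsomes from liver (Homo sapiens) for metabolic stability, using NADPH, with a stated time of 10 min; on this read-out lower numbers stand for a less stable compound and higher numbers for a more stable compound:
Compound 1, `CCCCc1nc(=O)c(S(=O)(=O)c2ccc(-c3ccc(F)nc3)cc2)c(O)n1-c1c(OC)cccc1OC`, gives 100%.
Compound 2, `CCCCc1nc(=O)c(S(=O)(=O)c2ccc(-n3ccccc3=O)cc2)c(O)n1-c1c(OC)cccc1OC`, gives 87%.

Within the data shown here, of these two numbers compound 2 stands lowest; its nearest neighbour is compound 1, and the only measured step, a number 13 percentage points lower from compound 1 to compound 2 (beyond the scatter), is a swap of one six-membered ring for another on the same aromatic carbon.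

Compound 3, `CCCCc1nc(=O)c(S(=O)(=O)c2ccccc2)c(O)n1-c1c(OC)cccc1OC`, differs from compound 2 by a hydrogen atom in place of a group of 7 heavy atoms (5 carbon, 1 nitrogen, 1 oxygen; one six-membered aromatic ring with 1 hetero atom), on an aromatic carbon. Among the measured compounds shown here, no measured step removes this group outright, so the step of a number 13 percentage points lower from compound 1 to compound 2 (beyond the scatter) is the only guide, and it bears only loosely on the change at hand. Both measured compounds sit in the upper part of the scale, so a step of similar size in either direction, or none beyond the scatter, seems most plausible. The step from compound 2 to compound 3 in this assay is estimated as a number 1 percentage points higher from compound 2 to compound 3 (within the scatter). Compound 3 is therefore expected to give about 88%, with a range from 65% to 100%.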

Compound 3, percent of the compound remaining: 89%
Compound 3: the middle estimate sits 1 percentage points below what was measured, and the stated range covers the measured number.
By their numbers in this assay, from the lowest: compounds 2 and 3 (each within the scatter of the next); then compound 1.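

In this assay, putting a hydrogen on this aromatic carbon in place of the ring group of compound 2 gives a number 2 percentage points higher from compound 2 to compound 3 (within the scatter) and so leaves the reading unchanged within normal variation, which means a large ring group at this place is not needed for a reading of this level. The same hydrogen in place of 6-fluoropyridin-3-yl gives a number 11 percentage points lower from compound 1 to compound 3 (beyond the scatter) and so, among these three compounds, only that group stands apart from the other two. Nothing measured here explains why the numbers fall this way. From the compounds shown here alone, it remains open whether a small group on this carbon, such as a methyl, an amine or a carboxylic acid, would read like compound 3 or like compound 1. Going by these compounds, it is also open whether 6-fluoropyridin-3-yl would keep its reading with a nitrile in place of the fluorine.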